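A few compounds are considered here, and "the series" means these few. Any claim that something is new, unique, unknown or untested is made for them only; others in the source may bear on it.

Measured so far:
- Compound 1, `COc1ccc(Oc2ccc3c(NCCCNCc4cc(F)ccc4OC)ccnc3c2)cc1`, gives 14500 nM.
- Compound 2, `COc1ccc(F)cc1CNCCCNc1ccnc2cc(Cc3cc(C)cc(C)c3)ccc12`, gives 4200 nM.
- Compound 3, `COc1ccc(Oc2ccc3c(NCCCNCc4cccc(OC)c4O)ccnc3c2)cc1`, gives 14500 nM.

All three numbers come from a physicochemical assay for solubility, with a stated time of 18 h, at pH 7.4; on this read-out higher numbers stand for higher solubility and lower numbers for lower solubility. Compound 3 stands level with compound 1 at the digits shown, and the two of them are together the highest of the three numbers; compound 2 sits furthest away, with a 3.5-fold lower number from compound 1 to compound 2 (0.54 log units; beyond the scatter). Between compound 1 and compound 3 the change at the saturated chain carbon bound to an amine nitrogen left the number as it was: no change at the digits printed from compound 1 to compound 3 (within the scatter).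

Compound 4, `COc1cccc(CNCCCNc2ccnc3cc(CCC(C)C)ccc23)c1O`, has not yet been measured. It differs from compound 3 at an aromatic carbon of the shared core: isopentyl in place of 4-methoxyphenoxy on an aromatic carbon. Among the measured compounds shown here, the one measured step that touches the same place is the step from compound 1 to compound 2, where the 4-methoxyphenoxy group was likewise exchanged, giving a 3.5-fold lower number from compound 1 to compound 2 (0.54 log units; beyond the scatter). That single step points toward a lower number, of modest size, when the 4-methoxyphenoxy group leaves this position. The group entering here is not the one that entered there, so the size carries real uncertainty, but a drop beyond the scatter is expected: a 2.6-fold lower number from compound 3 to compound 4 (0.42 log units; beyond the scatter). Compound 4 is therefore estimated at 5500 nM, with a range from 2000 nM to 14500 nM.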

Compound 4, solubility: 4200 nM
Beside the measured number, compound 4's estimate is 1.3-fold (0.12 log units) above it; the range from low to high includes it.
By their numbers in this assay, from the lowest: compounds 2 and 4 (each within the scatter of the next); then compounds 1 and 3 (each within the scatter of the next).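

In this assay, exchanging 4-methoxyphenoxy for isopentyl on this aromatic carbon gives a 3.5-fold lower number from compound 3 to compound 4 (0.54 log units; beyond the scatter), the same size as the earlier exchange for 3,5-dimethylbenzyl, a 3.5-fold lower number from compound 1 to compound 2 (0.54 log units; beyond the scatter). The lower number therefore now appears with two different entering groups, one of which, isopentyl, has no ring and no hydrogen-bond acceptors, and it also appears with 2-hydroxy-3-methoxyphenyl rather than 5-fluoro-2-methoxyphenyl elsewhere in the molecule, so neither exchange at this position goes against the drop. Nothing shown here offers an explanation for why the number falls.

Going by these compounds, both entering groups are built from carbon alone, so it remains open whether a group with other atoms on this aromatic carbon, such as an amine, a carboxylic acid or a short ether chain, would keep the number close to that of compound 3 at 14500 nM. On these data alone, it is also open whether a smaller carbon group, such as methyl, would give a step of the same size, or whether the size of the entering group matters at all.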